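Swapping phenoxy for methylimidazolyl at one aromatic carbon

This account rests on a few compounds, and the source may have more. Where it says the series, first, only, none or still open, it means among the compounds named here.

Compound 2 `Cc1cc(Oc2ccccc2)c(S(C)(=O)=O)cc1C(=O)N=C(N)N` gives 10 nM in a functional assay for inhibition of sodium/hydrogen exchanger (Oryctolagus cuniculus) (on this read-out higher numbers stand for weaker inhibition and lower numbers for stronger inhibition), the lower of the two numbers shown, although compound 1 `Cc1cc(Br)c(S(C)(=O)=O)cc1C(=O)N=C(N)N` with 12 nM lies within the scatter of it. Compound 3 `Cc1cn(-c2cc(C)c(C(=O)N=C(N)N)cc2S(C)(=O)=O)cn1` differs from compound 2 by 4-methyl-1H-imidazol-1-yl in place of phenoxy on an aromatic carbon. Among the measured compounds shown here, the only measured step bearing on this, a 1.2-fold lower number from compound 1 to compound 2 (0.08 log units; within the scatter), exchanged a different group at this same aromatic carbon and stayed within the scatter, so a step of similar size is expected here, with a 1.5-fold higher number from compound 2 to compound 3 (0.18 log units; within the scatter) in no clear direction. Compound 3 is therefore estimated to give 15 nM in this assay, within 5 nM to 50 nM.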

Compound 3, half-maximal inhibitory concentration: 28 nM
The estimate for compound 3 lay 1.9-fold (0.27 log units) below the measured number, and the stated range covers the measured number.
By their numbers in this assay, from the lowest: compounds 2 and 1 (each within the scatter of the next); then compound 3.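

In this assay this aromatic carbon, ortho to a methylsulfonyl group, now shows that its group can matter: 4-methyl-1H-imidazol-1-yl gives a 2.8-fold higher number from compound 2 to compound 3 (0.45 log units; beyond the scatter) and a 2.3-fold higher number from compound 1 to compound 3 (0.37 log units; beyond the scatter). Both steps are modest but beyond the scatter, whereas bromo and phenoxy had stayed within the scatter of each other. Nothing available explains the higher number of compound 3.

Going by these compounds, it remains open whether the 4-methyl of the entering group contributes to this step, as an unsubstituted 1H-imidazol-1-yl would show. On these data alone, how an amine or a carboxylic acid would read at this carbon also remains open.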